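A few compounds are considered here, and "the series" means these few. Any claim that something is new, unique, unknown or untested is made for them only; others in the source may bear on it.

Measured compounds:
compound 1 `CC(=O)Nc1nc(-c2cccc(NS(=O)(=O)c3cccc(Br)c3)c2)cs1` — a functional assay on A-375 cells (Homo sapiens) for antiproliferative activity, read by trypan blue exclusion, with a stated time of 48 h, tested at 1 uM; a lower number here means a stronger effect, a higher number a weaker effect of the compound at the concentration tested: "not active" (no number reported)
compound 2 `C#Cc1ccc(S(=O)(=O)Nc2cccc(-c3csc(NC(C)=O)n3)c2)cc1` — this assay: 59.2%
compound 3 `CC(=O)Nc1nc(-c2cccc(NS(=O)(=O)c3ccc(C#CCCc4ccccc4)cc3)c2)cs1` — this assay: 11.5%

Compound 1 stands without a single number; in this assay compound 1 is recorded only as "not active" (no number reported). Compound 4 `CC(=O)Nc1nc(-c2cccc(NS(=O)(=O)c3cccc(C#CCO)c3)c2)cs1` is not yet measured. It differs from compound 1 by 3-hydroxyprop-1-yn-1-yl in place of bromo on an aromatic carbon, placed on an aromatic carbon of a six-membered aromatic ring of carbon only, meta to a large group.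

For the measured compounds named here, only one measured step concerns a change at a triple-bonded carbon: a number 47.7 percentage points lower from compound 2 to compound 3 (beyond the scatter). Going by the values given here, that step puts phenethyl in place of hydrogen on an existing alkyne, whereas the present change introduces an alkyne where bromo was, so it does not bear directly; no step covers the change itself. With compound 1 lacking a number, the direction can only be guessed from compound 2 carrying a terminal alkyne at 59.2%.

Compound 4 is estimated at 70%, expected between 40% and 100%.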

Compound 4, a percentage reported as activity, at one concentration (the size of the read-out at that concentration, not a potency): 85.4%
Estimate against measurement, compound 4: 15.4 percentage points below; the range from low to high includes it.
By their numbers in this assay, from the lowest: compound 3; then compound 2; then compound 4.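

For the compounds shown here, compound 1 is recorded as "not active" (no number reported) and compound 4 as 85.4%, and no step between them can be read. No measured evidence bears on this result. On these data alone, the effect of 3-hydroxyprop-1-yn-1-yl in place of bromo on the read-out remains open.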